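The compounds below may be only part of what the source reports. "The series", "measured", "known", "first", "only" and "open" are said of these compounds alone.

Compound 1 `CC(C)CC(=O)NCCCN1CCN(CCCNc2ccnc3cc(Cl)ccc23)CC1` carries an isobutylcarbonyl amide on the shared core. In an ADME assay on L6 cells (Rattus norvegicus) for cytotoxicity (on this read-out higher numbers stand for weaker inhibition and lower numbers for stronger inhibition), compound 1 gives "not determined" (no result reported), so no single number is available for it. Compound 3 `O=C(CCCC1CCCCC1)NCCCN1CCN(CCCNc2ccnc3cc(Cl)ccc23)CC1` likewise gives "not determined" (no result reported) in this assay. For the measured compounds named here, the only measured member of the series is compound 2 `CCc1ccc(C(=O)NCCCN2CCN(CCCNc3ccnc4cc(Cl)ccc34)CC2)cc1`, which in this assay gives 3900 nM. Compound 4 `O=C(CCCCc1ccccc1)NCCCN1CCN(CCCNc2ccnc3cc(Cl)ccc23)CC1` remains to be measured. The change from compound 1 to compound 4 is 3-phenylpropyl in place of isopropyl on a saturated chain carbon bound to a carbonyl carbon. Going by the values given here, with no step between measured compounds available, the size of this step in this assay cannot be read from the data. On general grounds a change of this kind in the amide side chain would be expected to shift the value only modestly, quite possibly within the usual scatter, with no clear direction. Taking compound 2 and its 3900 nM as the sole anchor, compound 4 is expected to come in near 3000 nM, within a range from 800 nM to 12000 nM.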

Compound 4, half-maximal inhibitory concentration: 9400 nM
Compound 4: the middle estimate sits 3.1-fold (0.50 log units) below what was measured; the measured number falls inside the stated range.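

In this assay the series now has its first readable step, which shows a 2.4-fold higher number from compound 2 to compound 4 (0.38 log units; beyond the scatter) with 4-phenylbutyl in place of 4-ethylphenyl on a carbonyl carbon. At this position, then, the two groups can be told apart: of these two compounds, the one with the open chain ending in a phenyl ring gives the higher number and so the weaker inhibition, a difference printed as beyond the scatter. The steps involving compound 1 and compound 3 cannot be read, and nothing measured here speaks to what lies behind the step.

The compounds shown leave open how far this holds for other chains, such as a shorter 2-phenylethyl group or a longer 6-phenylhexyl group. They also leave open what an amine or a carboxylic acid at the end of the chain would do to the number.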